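Aryl enone boron series: toward a 3-fluorophenyl analogue

A few compounds are considered here, and "the series" means these few. Any claim that something is new, unique, unknown or untested is made for them only; others in the source may bear on it.

Measured so far in a functional assay on HCT-116 cells (Homo sapiens) for cytotoxicity, read by MTT assay, with a stated time of 48 h; a higher number here means a weaker inhibitor, a lower number a stronger inhibitor:
- compound 1 `O=C(/C=C/c1ccc2c(c1)B(O)OC2)c1ccc(-c2ccccc2)cc1` gives 9500 nM
- compound 2 `O=C(/C=C/c1ccc2c(c1)B(O)OC2)c1ccco1` gives 24100 nM
- compound 3 `O=C(/C=C/c1ccc2c(c1)B(O)OC2)c1ccc(Br)cc1` gives 9900 nM

Compound 3 stands second highest of the three numbers. Its nearest neighbour is compound 1, with the pair lying within the scatter a 1.0-fold higher number from compound 1 to compound 3 (0.02 log units; within the scatter); the furthest is compound 2, from which the step of a 2.4-fold lower number from compound 2 to compound 3 (0.39 log units; beyond the scatter) is modest but beyond the scatter.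

Compound 4 `O=C(/C=C/c1ccc2c(c1)B(O)OC2)c1cccc(F)c1` differs from compound 3 in one place: 3-fluorophenyl in place of 4-bromophenyl on a carbonyl carbon. Going by the values given here, the only measured step on the same position, from compound 1 to compound 3, swapped one aryl substituent for another and moved nothing a 1.0-fold higher number from compound 1 to compound 3 (0.02 log units; within the scatter). The larger step, from compound 2 to compound 3, swapped a furan-2-yl for an aryl group and is not a close model for an aryl-to-aryl exchange. Compound 4 is therefore expected to sit near compound 3, with a step of a 1.1-fold higher number from compound 3 to compound 4 (0.05 log units; within the scatter) that stays within the scatter. The estimate for compound 4 in this assay is 11000 nM, expected between 5000 nM and 25000 nM.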

Compound 4, half-maximal inhibitory concentration: 6700 nM
For compound 4 the middle estimate is 1.6-fold (0.22 log units) above the measured one, and the stated range covers the measured number.
By their numbers in this assay, from the lowest: compounds 4, 1 and 3 (each within the scatter of the next); then compound 2.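

In this assay, 3-fluorophenyl in place of 4-bromophenyl on the carbonyl carbon gives a 1.5-fold lower number from compound 3 to compound 4 (0.17 log units; within the scatter), so a second aryl-to-aryl exchange at this position also leaves no change that can be read beyond the scatter. The step of a 3.6-fold lower number from compound 2 to compound 4 (0.56 log units; beyond the scatter) shows that the gap from the furan-2-yl compound is not confined to 4-bromophenyl, and that here it is a little wider, though still modest. No measurement offers a reason for either step.

The step to compound 4 changes the halogen and its place on the ring together, and these compounds cannot separate the two. Also open, going by these compounds, is whether an amine or a carboxylic acid on the phenyl ring would keep the numbers in this range.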